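The source may report more compounds than this note shows. Statements on the series, on what has been measured and on what is new or still open speak of the compounds shown alone.

Measured so far:
- compound 1, `O=C1O[C@@H](CO)CN1c1ccc(-n2cc(-c3ccccn3)cn2)c(F)c1`: > 400 ug/mL
- compound 2, `O=C1O[C@@H](CN2CCC(O)CC2)CN1c1ccc(-n2cc(-c3ccccn3)cn2)c(F)c1`: > 400 ug/mL
- compound 3, `CS(=O)(=O)NC[C@H]1CN(c2ccc(-n3cc(-c4ccccn4)cn3)c(F)c2)C(=O)O1`: 314 ug/mL

In an ADME assay on HEK293-A cells (Homo sapiens) for cytotoxicity, read by MTT assay, with a stated time of 48 h (on this read-out lower numbers stand for stronger inhibition and higher numbers for weaker inhibition), compound 1 gives only a limit of the assay, > 400 ug/mL. Compound 2 likewise gives only a limit, > 400 ug/mL. Among the compounds with values here, compound 3 gives 314 ug/mL, the one number among the three, and it sits near (the limit of > 400 ug/mL in this assay, at which 2 of the 3 values shown sit). The step of an at least 1.2-fold lower number from compound 1 to compound 3 (0.10 log units; that floor lies within the scatter) and the step of an at least 1.2-fold lower number from compound 2 to compound 3 (0.10 log units; that floor lies within the scatter) therefore carry only a floor, and the step that the two limits leave unreadable from compound 1 to compound 2 cannot be read at all.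

Compound 4, `CONC(=O)[C@H]1CN(c2ccc(-n3cc(-c4ccccn4)cn3)c(F)c2)C(=O)O1`, differs from compound 3 by methoxycarbamoyl in place of (methanesulfonamido)methyl on a saturated ring carbon. Within the data shown here, none of the measured steps alters this ring carbon; all three concern the chain carbon, so they offer no direct guide, and the values of compound 1 and compound 2 show little movement anywhere in this set. The expected step of a 1.1-fold higher number from compound 3 to compound 4 (0.05 log units; within the scatter) is therefore none beyond the scatter. Compound 4 is estimated at 350 ug/mL, between 150 ug/mL and 800 ug/mL, with a fair chance that this assay again reports only a limit.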

Compound 4, half-maximal inhibitory concentration: > 400 ug/mL
Compound 4: no number, only a limit (the forecaster's own chance of this, stated with the estimate: 45%); at least 1.1-fold (0.05 log units) between middle value and limit.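

Unlike the earlier steps, which alter a chain carbon, this change alters the saturated ring carbon next to the ring oxygen itself. Compound 4 gives in this assay only > 400 ug/mL as a limit of the assay. Methoxycarbamoyl in place of (methanesulfonamido)methyl thus gives an at least 1.2-fold higher number from compound 3 to compound 4 (0.10 log units; that floor lies within the scatter) and no change that can be read beyond the scatter, the steps that join compound 4 to compound 1 and compound 2 cannot be read, and little can be said about this position because most of the set rests on one limit: the limit of > 400 ug/mL in this assay, at which 3 of the 4 values shown sit.

How far any of these compounds lies from the others remains open, since only compound 3 gives a number. On these data alone, whether an amine or a carboxylic acid on this ring carbon would give a clearly lower number also remains open.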